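This account rests on a few compounds, and the source may have more. Where it says the series, first, only, none or still open, it means among the compounds named here.

Compound 2 `COc1cc(C(c2ccc(O)c(OC)c2)[C@H](CF)C(C)C)ccc1O` stands second highest of the three numbers in a functional assay on HeLa cells (Homo sapiens) for cytotoxicity, read by WST assay, with a stated time of 48 h (on this read-out higher numbers stand for weaker inhibition and lower numbers for stronger inhibition), at 19000 nM. Compound 1 `COC[C@H](C)[C@@H](C)C(c1ccc(O)c(OC)c1)c1ccc(O)c(OC)c1` gives 77000 nM in this assay, and compound 3 `CCCCCCCC[C@H](C(C)C)C(c1ccc(O)c(OC)c1)c1ccc(O)c(OC)c1` gives 3100 nM. The step of a 4.1-fold lower number from compound 1 to compound 2 (0.61 log units; beyond the scatter) and the step of a 6.1-fold lower number from compound 2 to compound 3 (0.79 log units; beyond the scatter) are both modest and beyond the scatter. Compound 4 `COc1cc(C(c2ccc(O)c(OC)c2)[C@H](C)[C@H](C)CF)ccc1O` differs from compound 2 in one place: 2-(fluoromethyl)-1-methylpropyl in place of 1-(fluoromethyl)-2-methylpropyl on a saturated chain carbon bound to two aromatic carbons. The change rearranges the same atoms, so neither measured step matches it directly. The step from compound 1 to compound 2 is the nearer guide, since compound 1 also carries its branching at the 2-position of the chain; compound 4 is expected to fall between compound 1 and compound 2 in this assay, with a step of a 1.6-fold higher number from compound 2 to compound 4 (0.20 log units; within the scatter) that may not clear the scatter. Compound 4 is therefore estimated at 30000 nM in this assay, within a range from 12000 nM to 75000 nM.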

Compound 4, half-maximal inhibitory concentration: 75000 nM
Compound 4: middle estimate off by 2.5-fold (0.40 log units), on the low side, within the range that was stated.
By their numbers in this assay, from the lowest: compound 3; then compound 2; then compounds 4 and 1 (each within the scatter of the next).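

Rearranging the same atoms is not a neutral change on a saturated chain carbon bound to two aromatic carbons: in this assay, 2-(fluoromethyl)-1-methylpropyl in place of 1-(fluoromethyl)-2-methylpropyl gives a 3.9-fold higher number from compound 2 to compound 4 (0.60 log units; beyond the scatter). With the branching kept as in compound 1, 1-(fluoromethyl)ethyl in place of 1-(methoxymethyl)ethyl on a saturated chain carbon bound to two saturated chain carbons gives a 1.0-fold lower number from compound 1 to compound 4 (0.01 log units; within the scatter), so this read-out does not separate the fluoro and methoxy ends in this arrangement. No measurement at hand accounts for either result. The compounds shown leave open whether an amine or a carboxylic acid in place of the fluoro or methoxy end would separate from compound 1 and compound 4. They also leave open whether a heptyl group in place of fluoro would give a step of similar size in the arrangement of compound 4.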